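This account rests on a few compounds, and the source may have more. Where it says the series, first, only, none or still open, it means among the compounds named here.

In an assay on HEK293 cells for displacement of a labelled ligand from Melanocortin receptor 4 (Homo sapiens) (on this read-out higher numbers stand for weaker inhibition and lower numbers for stronger inhibition), three compounds have been measured. Compound 1 `CC(C)C[C@H](N)c1cc(C(F)(F)F)ccc1N1CCN(C(=O)CCC(N)=O)CC1` gives > 10000 nM, which is a limit of the assay rather than a number. Compound 2 `CC(C)C[C@H](N)c1cc(C(F)(F)F)ccc1N1CCN(C(=O)COc2cccc(Cl)c2Cl)CC1` gives 2500 nM. Compound 3 `Cc1ccc(N2CCN(C(=O)[C@H](C)Cc3ccc(Cl)cc3F)CC2)c([C@@H](N)CC(C)C)c1` gives 20 nM.

Among the two numbers shown, compound 2 carries the highest; compound 3 gives a markedly lower number, though the two structures differ in more than one place and no single step connects them. Compound 4 `CC(C)C[C@H](N)c1cc(C(F)(F)F)ccc1N1CCN(C(=O)CCC(=O)c2ccc(Cl)cc2)CC1` differs from compound 2 in one place: ((4-chlorophenyl)carbonyl)methyl in place of 2,3-dichlorophenoxy on a saturated chain carbon bound to a carbonyl carbon.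

Going by the values given here, only one measured step bears on this position, namely an at least 4.0-fold lower number from compound 1 to compound 2 (0.60 log units; beyond the scatter), and it rests on (the limit of > 10000 nM in this assay, at which 1 of the 3 values shown sits), so its true size is open. That step replaced a short polar chain end with an aromatic group; the step to compound 4 instead exchanges one aromatic group for another of similar size. On this basis the author expects the number for compound 4 to move little beyond the scatter, with a 1.3-fold lower number from compound 2 to compound 4 (0.10 log units; within the scatter) as the estimated step. The expected value for compound 4 in this assay is 2000 nM, within the range 500 nM to 8000 nM.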

Compound 4, inhibition constant: 820 nM
Compound 4: middle estimate off by 2.4-fold (0.39 log units), on the high side, and the stated range covers the measured number.
By their numbers in this assay, from the lowest: compound 3; then compound 4; then compound 2. At a limit, above all of these: compound 1.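

In this assay, the exchange at this position, on a saturated chain carbon bound to a carbonyl carbon, gives a 3.0-fold lower number from compound 2 to compound 4 (0.48 log units; beyond the scatter). This shows that the position does not treat all aromatic end groups alike, since two groups that each hold one six-membered aromatic ring of carbon only and one hydrogen-bond acceptor give numbers that lie apart beyond the scatter. Placing 4-chlorophenyl instead of amino on a carbonyl carbon gives an at least 12-fold lower number from compound 1 to compound 4 (1.08 log units; beyond the scatter), but compound 1 stands at > 10000 nM, which is a limit of the assay and not a number, and the true size of this step stays open because it rests on: the limit of > 10000 nM in this assay, at which 1 of the 4 values shown sits.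

The compounds shown do not separate what carries the step from compound 2, as the chlorine pattern on the ring, the oxygen and the carbonyl, and the chain length all change together. As far as these compounds go, whether a 4-chlorophenoxy group, a 4-chlorophenyl group on a longer chain without the carbonyl, or an amine at the chain end would give a lower or a higher number stays open, as does whether the same exchange would hold on the core of compound 3.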